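Hemolysis series: methoxy for chloro on the terminal ring

The source may report more compounds than this note shows. Statements on the series, on what has been measured and on what is new or still open speak of the compounds shown alone.

Compound 2 `N=C(N)c1ccc(-c2ccc(-c3ccc(Cl)cc3)o2)o1` gives 70.7% in an ADME assay on cells (Erythrocyte, Homo sapiens) for activation, read by hemolysis, with a stated time of 30 min, tested at 5 mM; a higher number here means a stronger effect of the compound at the concentration tested, a lower number a weaker effect. Compound 1 `N=C(N)c1ccc(-c2ccc(-c3ccc(F)cc3)o2)o1` gives 66.3%, within the scatter of compound 2, whereas compound 3 `N=C(N)c1ccc(-c2ccc(-c3ccc(Cl)cc3)s2)s1` gives 49%, beyond the scatter. For the measured compounds named here, the only single-place step known, a number 4.4 percentage points higher from compound 1 to compound 2 (within the scatter), is a halogen exchange and lies within the scatter.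

Compound 4 `COc1ccc(-c2ccc(-c3ccc(C(=N)N)o3)o2)cc1` differs from compound 2 as follows: methoxy in place of chloro on an aromatic carbon. Going by the values given here, no measured step replaces a halogen with a methoxy, so the exchange of compound 1 for compound 2 is the nearest guide, and it bears only loosely. A step within the scatter is therefore expected in this assay for compound 4, with no preferred direction. The estimate for compound 4 is 65%, in the range 50% to 80%, corresponding to an expected step of a number 5.7 percentage points lower from compound 2 to compound 4 (within the scatter).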

Compound 4, a percentage reported as activity, at one concentration (the size of the read-out at that concentration, not a potency): 36.3%
Compound 4: the middle estimate sits 28.7 percentage points above what was measured; the whole stated range lies above it.
By their numbers in this assay, from the lowest: compound 4; then compound 3; then compounds 1 and 2 (each within the scatter of the next).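

Para to a large group, the position proves sensitive to what it carries in this assay: methoxy in place of chloro gives a large fall (a number 34.4 percentage points lower from compound 2 to compound 4 (beyond the scatter)), and methoxy in place of fluoro a similar one (a number 30 percentage points lower from compound 1 to compound 4 (beyond the scatter)). The exchange between the two halogens stayed within the scatter, so here only the change to methoxy moves the read-out beyond it. Nothing measured on hand accounts for this fall.

Still open, as far as these compounds go, is whether methyl, hydroxy or an amine at this position would sit with the halogens or with methoxy. Also open, from the compounds shown here alone, is whether methoxy acts the same way on the core of compound 3.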